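Replacing the amide group: compound 3 to compound 4

The compounds below may be only part of what the source reports. "The series", "measured", "known", "first", "only" and "open" are said of these compounds alone.

Compound 1 (`Cc1cc(NC(=O)[C@H]2CN(C)C[C@@H]2c2ccc(/C=C/C(=O)Nc3ccccc3N)cc2)ccc1Cl`), compound 2 (`Cc1ccc(NC(=O)[C@H]2CN(C)C[C@@H]2c2ccc(/C=C/C(=O)Nc3ccccc3N)cc2)cn1`) and compound 3 (`CN1C[C@H](C(=O)Nc2ccccn2)[C@@H](c2ccc(/C=C/C(=O)Nc3ccccc3N)cc2)C1`) share one core and differ only in the group on the amide-type nitrogen. In an in vitro ADME assay on microsomes from liver (Mus musculus) for pharmacokinetics, read by LC-MS, with a stated time of 10 min, tested at 1 uM (on this read-out higher numbers stand for fast clearance and lower numbers for slow clearance), compound 1 gives 65 mL/min/kg and compound 2 gives 57 mL/min/kg. Compound 3 gives 40 mL/min/kg, which stands within the scatter of both other values.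

The next structure is compound 4 (`CN1C[C@H](C(=O)N2CCCCC2)[C@@H](c2ccc(/C=C/C(=O)Nc3ccccc3N)cc2)C1`), and the change is piperidin-1-yl in place of (pyridin-2-yl)amino on a carbonyl carbon. It places a six-membered non-aromatic ring on a carbonyl carbon, whereas all three measured compounds carry a six-membered aromatic ring on the amide-type nitrogen.

The closest evidence is a 1.6-fold lower number from compound 1 to compound 3 (0.21 log units; within the scatter) and a 1.4-fold lower number from compound 2 to compound 3 (0.15 log units; within the scatter), and a 1.1-fold lower number from compound 1 to compound 2 (0.06 log units; within the scatter) completes the set. All three steps lie within the scatter, but none of them introduces a non-aromatic ring, so they bear on this change only indirectly. On these steps, no shift beyond the scatter is expected in this assay. The expected step is a 1.4-fold higher number from compound 3 to compound 4 (0.14 log units; within the scatter).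

For compound 4 the estimated clearance is 55 mL/min/kg, with an expected range of 28 mL/min/kg to 105 mL/min/kg.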

Compound 4, clearance: 42 mL/min/kg
Estimate against measurement, compound 4: 1.3-fold (0.12 log units) above, and the stated range covers the measured number.
By their numbers in this assay, from the lowest: compounds 3, 4, 2 and 1 (each within the scatter of the next).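

In this assay, the first non-aromatic ring on this carbonyl carbon, piperidin-1-yl in place of (pyridin-2-yl)amino, gives a 1.1-fold higher number from compound 3 to compound 4 (0.02 log units; within the scatter). Among these compounds, the exchange also removes the amide hydrogen, so at this position neither an aromatic ring nor that hydrogen is needed to keep the clearance number within the scatter of the earlier compounds. The result holds against the other two groups as well, with a 1.4-fold lower number from compound 2 to compound 4 (0.13 log units; within the scatter) and a 1.5-fold lower number from compound 1 to compound 4 (0.19 log units; within the scatter), and nothing shown gives a cause for it.

On these data alone, it remains open whether a piperidin-1-yl ring bearing a carboxylic acid or an amine would keep the number in this range. The same applies to morpholin-4-yl or an open diethylamino group on the same carbonyl carbon.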